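From Isopropyl to 2-Methoxyethyl on an Aromatic Nitrogen

The source may report more compounds than this note shows. Statements on the series, on what has been measured and on what is new or still open speak of the compounds shown alone.

Measured in a functional assay on FaDu cells (Homo sapiens) for cytotoxicity, read by MTT assay, with a stated time of 72 h; on this read-out lower numbers stand for higher toxicity in this test and higher numbers for lower toxicity in this test:
- compound 1 `COc1ccc(NC(=O)C(=O)c2cn(C(C)C)c3ccccc23)cc1`: 181 nM
- compound 2 `COc1ccc(NC(=O)C(=O)c2cn(C(C)C)c3ccccc23)cn1`: 85 nM
- compound 3 `CC(C)n1cc(C(=O)C(=O)Nc2cccnc2)c2ccccc21`: > 10000 nM (a limit of the assay, not a number)

Compound 1 holds the higher of the two exact numbers, and its nearest neighbour lies at a 2.1-fold lower number from compound 1 to compound 2 (0.33 log units; beyond the scatter). The value for compound 3 is only a limit.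

Compound 4 `COCCn1cc(C(=O)C(=O)Nc2ccc(OC)cc2)c2ccccc21` keeps the core of compound 1 and its 4-methoxyphenyl group. Going by the values given here, the one change is 2-methoxyethyl in place of isopropyl on an aromatic nitrogen.

Among the compounds with values here, no measured step touches that nitrogen. All three measured steps alter the group on the amide-type nitrogen instead. Two of them are large, an at least 55-fold higher number from compound 1 to compound 3 (1.74 log units; beyond the scatter) and an at least 110-fold higher number from compound 2 to compound 3 (2.07 log units; beyond the scatter), so this assay can respond sharply to a structural change, though these steps occurred at another place. They give no direct guide to the size or direction of this step, so the range must stay wide.

A modest rise is the working expectation, and the expected step is a 2.2-fold higher number from compound 1 to compound 4 (0.34 log units; beyond the scatter). The estimated value for compound 4 is 400 nM, with an expected range from 100 nM to 2000 nM.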

Compound 4, concentration lethal to 50% of the cells: 59 nM
Estimate against measurement, compound 4: 6.8-fold (0.83 log units) above; the measured number lies below the stated range.
By their numbers in this assay, from the lowest: compounds 4 and 2 (each within the scatter of the next); then compound 1. At a limit, above all of these: compound 3.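

Going by these compounds alone, changing the nitrogen of the shared core, a place that no earlier step touched, also moves the result in this assay: replacing isopropyl with 2-methoxyethyl gives a 3.1-fold lower number from compound 1 to compound 4 (0.49 log units; beyond the scatter) and so a higher toxicity in this test. The position is therefore not silent, and this small branched group can give way to a slightly larger open chain carrying an oxygen without any loss of toxicity. This single pair shows the size and direction of the change but not its cause, and no measurement at hand bears on why the number falls.

The compounds shown cannot separate the part played by the ether oxygen from that of the chain itself, and a plain butyl chain, a longer chain with the oxygen further out, or a chain ending in an amine or a carboxylic acid would each help to tell these apart. Going by these compounds, it also remains open whether 2-methoxyethyl would have a similar effect with the 6-methoxypyridin-3-yl group of compound 2 on the amide-type nitrogen, as the change has been seen here only with the 4-methoxyphenyl group.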